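Removing a Protecting Ring: The Paw-Edema Number

The source may hold more compounds than are shown below. What is called first, only, known or untested is meant among the compounds shown, and "the series" means these compounds.

Of the compounds shown here, three sharing one core have been tested in a functional assay on the whole organism (strain Wistar albino) for inhibition, with Rattus norvegicus as the target, read by paw edema, with stated times of 30 min and 1.5 h, at a dose of 10 mg/kg by the oral route; a lower number here means less inhibition, a higher number more inhibition at the dose given (going by the name of the read-out). Compound 1 `COc1ccc(F)cc1-c1cccc(-c2n[nH]c(=O)o2)c1` carries a hydrogen on the aromatic nitrogen and gives 49%. Compound 2 `COc1ccc(F)cc1-c1cccc(-c2nn(CCCCF)c(=O)o2)c1` gives 67%, and compound 3 `COc1ccc(F)cc1-c1cccc(-c2nn(CCOC3CCCCO3)c(=O)o2)c1` gives 44%, the lowest of the three numbers, though its gap to compound 1 stays within the scatter. The two steps leading to compound 3 were a number 5 percentage points lower from compound 1 to compound 3 (within the scatter) and a number 23 percentage points lower from compound 2 to compound 3 (beyond the scatter).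

Compound 4 `COc1ccc(F)cc1-c1cccc(-c2nn(CCO)c(=O)o2)c1` differs from compound 3 by one change: hydrogen in place of oxan-2-yl on an oxygen on a saturated carbon. Among the compounds with values here, no measured step removes a group from this oxygen, so the closest guide is the step from the bare hydrogen of compound 1 to the 2-((oxan-2-yl)oxy)ethyl of compound 3, which lay within the scatter. Compound 4 is therefore expected to sit close to compound 3 and compound 1, with a step of a number 4 percentage points higher from compound 3 to compound 4 (within the scatter). For compound 4 the estimated value in this assay is 48%, within a range from 32% to 64%.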

Compound 4, a percentage reported as inhibition, in the whole organism at one dose (the size of the read-out at that dose, not a potency): 53%
Compound 4: middle estimate off by 5 percentage points, on the low side; the measured number falls inside the stated range.
By their numbers in this assay, from the lowest: compounds 3, 1 and 4 (each within the scatter of the next); then compound 2.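

In this assay, swapping the oxan-2-yl on the chain oxygen for hydrogen, which leaves a free hydroxy, gives a number 9 percentage points higher from compound 3 to compound 4 (within the scatter), so removing this ring makes no readable difference to the number. The resulting 2-hydroxyethyl on the aromatic nitrogen also stays level with the bare hydrogen, at a number 4 percentage points higher from compound 1 to compound 4 (within the scatter), whereas the 4-fluorobutyl remains apart from it, with a number 14 percentage points lower from compound 2 to compound 4 (beyond the scatter). Nothing available explains this difference between the two chains.

The compounds shown leave open whether the fluorine or the length of the chain sets compound 2 apart: 4-fluorobutyl and 2-hydroxyethyl differ in both. A plain butyl or a 4-hydroxybutyl on the aromatic nitrogen would separate these two features, and an amine at the chain end would pose a further question.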